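Compound 3 to compound 4: a larger group on the nitrogen

The source may hold more compounds than are shown below. What is called first, only, known or untested is meant among the compounds shown, and "the series" means these compounds.

In a functional assay on OVCAR-3 cells (Homo sapiens) for antiproliferative activity, read by MTT assay, with a stated time of 24 h (a higher number here means a weaker inhibitor, a lower number a stronger inhibitor), compound 1 `O=C(NNc1cccc(Cl)c1)c1ccc(NS(=O)(=O)c2cnc(O)nc2O)cc1` gives 8410 nM. Compound 3 `O=C(NNc1ccccc1F)c1cccc(NS(=O)(=O)c2cnc(O)nc2O)c1` gives 17000 nM, the higher of the two actual numbers, which makes it the weaker inhibitor of this pair. Compound 2 `O=C(NNc1ccc(F)cc1)c1ccc(NS(=O)(=O)c2cnc(O)nc2O)cc1` gives > 20000 nM, which is a limit of the assay and not a number. Compound 4 `O=C(NNC(=O)c1cccc(NS(=O)(=O)c2cnc(O)nc2O)c1)c1ccc(F)cc1` carries (4-fluorophenyl)carbonyl in place of the 2-fluorophenyl of compound 3 on an amine nitrogen ((4-fluorophenyl)carbonyl in place of 2-fluorophenyl on an amine nitrogen). Going by the values given here, the only measured step, an at least 2.3-fold higher number from compound 1 to compound 2 (0.37 log units; beyond the scatter), put 4-fluorophenyl in place of 3-chlorophenyl, a different change that offers only loose guidance. No step beyond the scatter is therefore expected in this assay. The expected change is a 1.1-fold lower number from compound 3 to compound 4 (0.05 log units; within the scatter). Compound 4 is estimated at 15000 nM, within an expected range of 6000 nM to 35000 nM.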

Compound 4, half-maximal inhibitory concentration: > 20000 nM
Compound 4 gave a limit, no number; the forecaster's own chance of this, stated with the estimate: 35%; at least 1.3-fold (0.12 log units) between middle value and limit.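

In this assay, going by these compounds alone, the earlier compounds carried only a substituted phenyl on this amine nitrogen, and the change to (4-fluorophenyl)carbonyl gives an at least 1.1-fold higher number from compound 3 to compound 4 (0.07 log units; that floor lies within the scatter). Compound 4 gives > 20000 nM, which is a limit of the assay and not a number. Adding a carbonyl here therefore shows no stronger inhibition, but the size of the loss, if any, stays hidden: the limit of > 20000 nM in this assay, at which 2 of the 4 values shown sit.

From the compounds shown here alone, how far compound 4 lies past that limit remains open. So does whether a smaller acetyl group or a benzyl group on this nitrogen would give a measurable number.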